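The source may hold more compounds than are shown below. What is called first, only, known or untested is meant among the compounds shown, and "the series" means these compounds.

Measured so far in a functional assay, read by spectrophotometry, with a stated time of 15 min; on this read-out higher numbers stand for weaker inhibition and lower numbers for stronger inhibition:
compound 1 `Cc1nc2c3ccccc3ccc2c2nc3c(ccc4ccccc43)c(-c3nccnc3N)c12` — 47.8 ug/mL
compound 2 `Cc1nc2c3ccccc3ccc2c2nc3c(ccc4ccccc43)c(-c3cc([N+](=O)[O-])ccc3N)c12` — 43.3 ug/mL
compound 3 `Cc1nc2c3ccccc3ccc2c2nc3c(ccc4ccccc43)c(-c3ccccc3S)c12` — 49.6 ug/mL

The three numbers lie within the scatter of one another; compound 3 sits at the top edge of that cluster, with a 1.0-fold higher number from compound 1 to compound 3 (0.02 log units; within the scatter) and a 1.1-fold higher number from compound 2 to compound 3 (0.06 log units; within the scatter) both too small to separate it from the other two. All three compounds share the same core and differ only in the aryl group carried on one aromatic carbon of that core.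

Compound 4 `Cc1nc2c3ccccc3ccc2c2nc3c(ccc4ccccc43)c(-c3ccc(O)cc3)c12` continues the same kind of variation: 4-hydroxyphenyl in place of 2-sulfanylphenyl on an aromatic carbon. Among the measured compounds shown here, the steps that bear on this are the three exchanges already made at this position, a 1.1-fold lower number from compound 1 to compound 2 (0.04 log units; within the scatter), a 1.0-fold higher number from compound 1 to compound 3 (0.02 log units; within the scatter) and a 1.1-fold higher number from compound 2 to compound 3 (0.06 log units; within the scatter). None of them moved the read-out beyond the scatter, even though the groups exchanged were quite different from one another. On that basis the change from compound 3 to compound 4 is expected to produce no step beyond the scatter either, a 1.1-fold lower number from compound 3 to compound 4 (0.02 log units; within the scatter). Compound 4 is therefore estimated at 47 ug/mL in this assay, with a range of 30 ug/mL to 75 ug/mL, the width of the range reflecting only the usual repeat-to-repeat scatter rather than any expected shift.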

Compound 4, half-maximal inhibitory concentration: 44.1 ug/mL
The estimate for compound 4 lay 1.1-fold (0.03 log units) above the measured number; low and high end bracket the measured number.
By their numbers in this assay, from the lowest: compounds 2, 4, 1 and 3 (each within the scatter of the next).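

In this assay, among the compounds shown here, 4-hydroxyphenyl is the first group at this position that carries neither an amino nor a sulfanyl group, yet exchanging sulfanyl-bearing 2-sulfanylphenyl for it leaves the read-out within the scatter (a 1.1-fold lower number from compound 3 to compound 4 (0.05 log units; within the scatter)). The same holds against the two amino-bearing groups, with (a 1.0-fold higher number from compound 2 to compound 4 (0.01 log units; within the scatter)) and (a 1.1-fold lower number from compound 1 to compound 4 (0.03 log units; within the scatter)), so all four compounds now lie within the scatter of one another and no aryl group shown on this aromatic carbon separates from the rest. Nothing available explains why these exchanges leave the read-out within the scatter.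

The compounds shown all carry a six-membered aromatic ring at this position, so it remains open whether a carboxylic acid, an aminoalkyl chain, a saturated ring such as piperidine or a simple methyl group there would give a step beyond the scatter. Also open, from the compounds shown here alone, is whether the read-out responds to changes elsewhere on the shared core, such as replacing its methyl group with an ethyl group or an amine.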